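The compounds below may be only part of what the source reports. "The series", "measured", "known", "first", "only" and "open" are said of these compounds alone.

In an ADME assay on HCT-116 cells (Homo sapiens) for cytotoxicity, read by CellTiter-Glo, with a stated time of 72 h (on this read-out higher numbers stand for weaker inhibition and lower numbers for stronger inhibition), compound 1 `CC1CCN(C2CCN(S(=O)(=O)c3cccnc3Cl)CC2)CC1` gives > 10000 nM, which is a limit. Compound 2 `CC1CCN(C2CCN(S(=O)(=O)c3cccc(N)c3)CC2)CC1` gives > 5000 nM, also a limit, so compound 2 has no number to start from. Going by the values given here, the only measured step, a step that the two limits leave unreadable from compound 1 to compound 2, has no readable size and gives no scale. Compound 3 `CC1CCN(C2CCN(S(=O)(=O)c3cccc(-c4ccc(F)cc4)c3)CC2)CC1` differs from compound 2 by 4-fluorophenyl in place of amino on an aromatic carbon, meta to a large group. The expected step that the limit leaves unreadable from compound 2 to compound 3 is only a rough estimate, with no firm direction. For compound 3 the estimated value is 7000 nM, with an expected range of 2500 nM to 20000 nM, and another limit is likely.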

Compound 3, half-maximal inhibitory concentration: > 5000 nM
Compound 3: no number, only a limit; the forecaster's own chance of this, stated with the estimate: 60%; the middle value does not contradict the limit.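

Going by these compounds alone, compound 2 and compound 3 both give only limits, so no step between them can be read. The compounds shown leave open whether any change on the shared core gives a readable number in this assay.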